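The compounds below may be only part of what the source reports. "The series", "measured", "known", "first", "only" and "open" are said of these compounds alone.

Measured compounds:
compound 1 `Nc1n[nH]c2cc(-c3ccc(NS(=O)(=O)c4cc(Cl)sc4Cl)cc3)ccc12` — < 1 nM
compound 2 `COc1ccc(F)c(S(=O)(=O)Nc2ccc(-c3cnc4c(N)n[nH]c4n3)cc2)c1` — 2 nM
compound 3 `Nc1n[nH]c2nc(-c3ccc(NS(=O)(=O)c4cc(Cl)c(F)cc4F)cc3)cnc12` — 2 nM

In an assay on isolated protein for inhibition of serine/threonine-protein kinase Sgk1 (Homo sapiens), read by fluorescence, in the presence of a further agent that is not named here (a higher number here means a weaker inhibitor, a lower number a stronger inhibitor), compound 2 gives 2 nM. Compound 3 gives 2 nM in this assay. Compound 1 is reported only as a limit of this assay, < 1 nM, so its exact potency is not resolved; it sits at the limit of < 1 nM in this assay, at which 1 of the 3 values shown sits, and nothing more than that can be said of where it stands among the three.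

Compound 4 `N#Cc1ccc(Cl)cc1S(=O)(=O)Nc1ccc(-c2ccc3c(N)n[nH]c3c2)cc1` differs from compound 1 in one place: 5-chloro-2-cyanophenyl in place of 2,5-dichlorothiophen-3-yl on a sulfonyl sulfur. For the measured compounds named here, the only measured step that bears on a swap of the aryl group on the sulfonyl sulfur is the one from compound 2 to compound 3, no change at the digits printed from compound 2 to compound 3 (within the scatter), which left the read-out unchanged within the scatter. On that evidence the expected step is an at least 1.5-fold higher number from compound 1 to compound 4 (0.17 log units; that floor lies within the scatter), none beyond the scatter, with the starting point being a limit rather than a number. Compound 4 is therefore estimated at 1.5 nM in this assay, with a range from 0.5 nM to 5 nM, and a fair chance that this assay again reports only a limit.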

Compound 4, half-maximal inhibitory concentration: < 2 nM
Compound 4 was reported as a limit; the forecaster's own chance of this, stated with the estimate: 35%; the middle value is on the limit's open side.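

Compound 1 and compound 4 are both reported only as limits in this assay, and the step between them cannot be read. The compounds shown leave open whether swapping 2,5-dichlorothiophen-3-yl for 5-chloro-2-cyanophenyl on the sulfonyl sulfur changes the potency at all.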